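Chlorophenyl step in a series held at a limit

The compounds below may be only part of what the source reports. "The series", "measured", "known", "first", "only" and "open" are said of these compounds alone.

Measured so far in a functional assay on NCI-H460 cells (Homo sapiens) for cytotoxicity, read by sulforhodamine B assay (a lower number here means that less compound is tolerated, a higher number that more compound is tolerated), for three compounds
compound 1 `COc1ccc(/C=N\NC(=S)NC(C)(C)CCC[C@](C)(O)[C@@H]2CC=C(C)CC2)cc1` gives > 100000 nM as a limit
compound 2 `CC1=CC[C@@H]([C@@](C)(O)CCCC(C)(C)NC(=S)N/N=C\c2ccccc2[N+](=O)[O-])CC1` gives > 100000 nM as a limit
compound 3 `CC1=CC[C@@H]([C@@](C)(O)CCCC(C)(C)NC(=S)N/N=C\c2ccc([N+](=O)[O-])cc2)CC1` gives > 100000 nM as a limit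

Compound 1 stands at > 100000 nM in this assay and this is a limit, not a number. The next case is compound 4 `CC1=CC[C@@H]([C@@](C)(O)CCCC(C)(C)NC(=S)N/N=C\c2cccc(Cl)c2)CC1` where the change is 3-chlorophenyl in place of 4-methoxyphenyl on a carbon with a double bond to nitrogen in the form of 3-chlorophenyl in place of 4-methoxyphenyl on a carbon with a double bond to nitrogen.

The measured steps that bear on it are a step that the two limits leave unreadable from compound 1 to compound 2 and a step that the two limits leave unreadable from compound 1 to compound 3 and also a step that the two limits leave unreadable from compound 2 to compound 3 so none of them gives a size. All the evidence consists of the limit of > 100000 nM in this assay, at which 3 of the 3 values shown sit, and no direction can be drawn from it. The expected change is a number no higher from compound 1 to compound 4 (the limit leaves the size open) with no step beyond the scatter foreseen. Compound 4 is estimated at 100000 nM with an expected range from 40000 nM to 200000 nM in this assay and a report as a limit alone is likely.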

Compound 4, concentration lethal to 50% of the cells: > 100000 nM
Compound 4 gave a limit, no number (the forecaster's own chance of this, stated with the estimate: 75%); the middle value sits exactly at the limit.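

Among these compounds, no step between compound 4 and compound 1, compound 2 or compound 3 can be read in this assay, and all four compounds share one limit: the limit of > 100000 nM in this assay, at which 4 of the 4 values shown sit. The compounds shown leave open which group on the carbon with a double bond to nitrogen, if any, would give a readable number in this assay.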